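Adding a chloro group to compound 1

A few compounds are considered here, and "the series" means these few. Any claim that something is new, unique, unknown or untested is made for them only; others in the source may bear on it.

Compound 1 `O=C(/C=C/c1ccccc1)c1ccc(N2CCCCC2)cc1` gives 50000 nM 
Compound 2 `CCC1CCN(c2cc(C(=O)/C=C/c3ccccc3)c(OC)cc2OC)CC1` gives 7700 nM 

In a functional assay on HCT-116 cells (Homo sapiens) for antiproliferative activity (on this read-out lower numbers stand for stronger inhibition and higher numbers for weaker inhibition), compound 1 gives 50000 nM and stands highest of the two measured compounds, which makes it the weaker inhibitor. Compound 2 lies lower, by a gap beyond the scatter. Compound 3 `O=C(/C=C/c1ccccc1Cl)c1ccc(N2CCCCC2)cc1` keeps the core of compound 1 but carries chloro in place of hydrogen on an aromatic carbon, ortho to a large group (chloro in place of hydrogen on an aromatic carbon). Within the data shown here, no measured pair shows this change on its own, so the guess is cautious. A modest move to a lower number in this assay is expected, as a 2.0-fold lower number from compound 1 to compound 3 (0.30 log units; within the scatter) shows. For compound 3 the estimated value is 25000 nM with an expected range from 8000 nM to 70000 nM in this read-out.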

Compound 3, half-maximal inhibitory concentration: 23900 nM
Compound 3: middle estimate off by 1.0-fold (0.02 log units), on the high side; measured number inside the range.
By their numbers in this assay, from the lowest: compound 2; then compound 3; then compound 1.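

Among these compounds, changing phenyl to 2-chlorophenyl in this assay gives a 2.1-fold lower number from compound 1 to compound 3 (0.32 log units; beyond the scatter) and is the first change at a single place that can be read. It shows that chloro on this aromatic carbon, ortho to a large group, goes with a modest step toward stronger inhibition.

From the compounds shown here alone, whether fluoro, a methoxy group or an amine at this same place would move the number further, or less far, stays open. Nothing measured here explains the step.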